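This account rests on a few compounds, and the source may have more. Where it says the series, first, only, none or still open, it means among the compounds named here.

Compound 1, `CCN(CC)Cc1cc(Nc2nc3ccccc3n2Cc2ccc(C(F)(F)F)cc2)ccc1O`, anchors this short series. Among the measured compounds shown here, in an ADME assay on CHO cells (Cricetulus griseus) for inhibition, read by MTT assay (on this read-out higher numbers stand for weaker inhibition and lower numbers for stronger inhibition), compound 1 gives 17500 nM, the only actual number among the three results. Compound 2, `CCN(CC)Cc1cccc(Nc2nc3ccccc3n2Cc2ccc(C(F)(F)F)cc2)c1O`, reads > 50000 nM, which is a limit and not a number. Compound 3, `CCN(CC)Cc1cc(Cl)cc(Nc2nc3ccccc3n2Cc2ccc(C(F)(F)F)cc2)c1O`, reads > 50000 nM, which is likewise a limit.

The next compound to be read is compound 4, `CCN(CC)Cc1cc(Nc2nc3ccccc3n2Cc2ccc(F)cc2)ccc1O`. Its difference from compound 1 is fluoro in place of trifluoromethyl on an aromatic carbon. In short, 4-(trifluoromethyl)benzyl becomes 4-fluorobenzyl.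

For the measured compounds named here, no measured step covers this change. Going by the values given here, the single step available is a step that the two limits leave unreadable from compound 2 to compound 3. It concerns chloro in place of hydrogen, not this substituent, and it supplies no size. The remaining evidence is the limit of > 50000 nM in this assay, at which 2 of the 3 values shown sit, which is again only a limit.

Among the compounds with values here, with no measured step on this group, no shift beyond the scatter is expected in this assay. The expectation therefore starts from compound 1 at 17500 nM, with a wide range on both sides. For compound 4 the estimated value is 20000 nM, with an expected range of 8000 nM to 50000 nM. The expected step is a 1.1-fold higher number from compound 1 to compound 4 (0.06 log units; within the scatter).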

Compound 4, half-maximal inhibitory concentration: 12000 nM
Beside the measured number, compound 4's estimate is 1.7-fold (0.22 log units) above it; measured number inside the range.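

In this assay, among the compounds shown here, the change from 4-(trifluoromethyl)benzyl to 4-fluorobenzyl gives a 1.5-fold lower number from compound 1 to compound 4 (0.16 log units; within the scatter) and this is the first step that can be read as a size. For the compounds shown here, on this aromatic carbon, para to a large group, the substituent therefore goes from 4 heavy atoms to 1 without a shift beyond the scatter, which the earlier compounds could not show because none of them varied this group. This is one pair on one background, so it marks this single exchange as tolerated in this read-out and sets no trend for the position, and nothing shown gives a reason for the outcome.

The step between compound 2 and compound 3 cannot be read, since both of its values are limits, so the effect of chloro on the shared core stays undefined. Also open, going by these compounds, is whether a carboxylic acid, a primary amine or a longer alkyl chain at this same carbon would move the number beyond the scatter, or whether the flat response holds only for halogen-bearing groups such as fluoro and trifluoromethyl.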